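Bromo in place of 1H-imidazol-4-yl: compound 2 to compound 4

The compounds below may be only part of what the source reports. "The series", "measured", "known", "first", "only" and "open" are said of these compounds alone.

- compound 1 `COc1cc(OC)c(OC)cc1/C=C/C(=O)c1cc(Cc2ccccc2)cc(Cc2ccccc2)c1` gives 2.17 ug/mL
- compound 2 `COc1cc(OC)c(OC)cc1/C=C/C(=O)c1ccc(-c2c[nH]cn2)cc1` gives 2.48 ug/mL
- compound 3 `COc1cc(OC)c(OC)cc1/C=C/C(=O)c1cccc([N+](=O)[O-])c1` gives 2.21 ug/mL

These three compounds share a core and were all read in a functional assay on cells (Erythrocyte, Rattus norvegicus) for inhibition, read by hemolysis, with a stated time of 1 h; on this read-out lower numbers stand for stronger inhibition and higher numbers for weaker inhibition. Compound 2 (2.48 ug/mL) stands within the scatter of both compound 3 (2.21 ug/mL) and compound 1 (2.17 ug/mL), so no order can be read among the three.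

Compound 4 `COc1cc(OC)c(OC)cc1/C=C/C(=O)c1ccc(Br)cc1` carries bromo in place of 1H-imidazol-4-yl on an aromatic carbon, para to a large group (bromo in place of 1H-imidazol-4-yl on an aromatic carbon). No measured pair isolates this replacement, so its effect is not shown directly. For the measured compounds named here, the only guide is that the substituents of the measured compounds differ considerably, yet all three values lie within the scatter of one another. On that basis, no change beyond the scatter is expected.

In this assay the expected step is a 1.1-fold lower number from compound 2 to compound 4 (0.03 log units; within the scatter) and should stay within the scatter. For compound 4 the estimated value is 2.3 ug/mL (expected range 1.2 ug/mL to 4.5 ug/mL).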

Compound 4, half-maximal inhibitory concentration: 2.3 ug/mL
The estimate for compound 4 equals the measured number at the digits printed; low and high end bracket the measured number.
By their numbers in this assay, from the lowest: compounds 1, 3, 4 and 2 (each within the scatter of the next).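

In this assay, the replacement of 1H-imidazol-4-yl by bromo on this aromatic carbon, para to a large group, gives a 1.1-fold lower number from compound 2 to compound 4 (0.03 log units; within the scatter), the first step read directly at this place. At this place, therefore, the number does not register the loss of the five-membered aromatic ring with its hydrogen-bond donor and acceptor, even though a single bromine atom takes its place. Nothing measured here bears on what lies behind this result.

Open, from the compounds shown here alone, is whether a carboxylic acid or an amine on this aromatic carbon would move the number beyond the scatter. Equally open, going by these compounds, is whether a hydroxyl in place of a methoxy group on the shared core would do so, or whether the number stays as flat there as it does here.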